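A few compounds are considered here, and "the series" means these few. Any claim that something is new, unique, unknown or untested is made for them only; others in the source may bear on it.

Measured so far:
- compound 1, `CCCOC(=O)c1[nH]cc(C(=O)OC(C)C(C)(C)C)c1C`, 4 nM
- compound 2, `CCN1CCC(OC(=O)c2[nH]cc(C(=O)OC(C)C(C)(C)C)c2C)C1`, 260 nM

In an assay on CHO cells for inhibition of metabotropic glutamate receptor 1 (Rattus norvegicus) (a higher number here means a weaker inhibitor, a lower number a stronger inhibitor), compound 1 gives 4 nM and compound 2 gives 260 nM. Among the measured compounds shown here, compound 2 therefore carries the highest number of the two, and its only neighbour is compound 1: the change from propyl to 1-ethylpyrrolidin-3-yl on the oxygen next to the carbonyl group gives a 65-fold higher number from compound 1 to compound 2 (1.81 log units; beyond the scatter).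

Compound 3, `Cc1c(C(=O)OC(C)C(C)(C)C)c[nH]c1C(=O)Oc1cccnc1`, is not yet measured. It differs from compound 2 in one place: pyridin-3-yl in place of 1-ethylpyrrolidin-3-yl on an oxygen next to a carbonyl group. For the measured compounds named here, only one measured step bears on this position, the step from compound 1 to compound 2, and it was large. It shows that the group on this oxygen matters a great deal to this assay, with the 1-ethylpyrrolidin-3-yl group giving the weaker of the two numbers. Going by the values given here, a step back toward a lower number is therefore expected for compound 3, but with wide uncertainty, since no measured compound carries a pyridin-3-yl group here. The expected step is an 8.7-fold lower number from compound 2 to compound 3 (0.94 log units; beyond the scatter), and the estimate for compound 3 in this assay is 30 nM, within the range 5 nM to 300 nM.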

Compound 3, half-maximal inhibitory concentration: 720 nM
For compound 3 the middle estimate is 24-fold (1.38 log units) below the measured one; measured number above the stated range.
By their numbers in this assay, from the lowest: compound 1; then compound 2; then compound 3.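

In this assay, the pyridin-3-yl group on this oxygen does not bring the number back toward that of the propyl compound: the change from 1-ethylpyrrolidin-3-yl to pyridin-3-yl moves it further up, though only modestly (a 2.8-fold higher number from compound 2 to compound 3 (0.44 log units; beyond the scatter)). Measured against propyl, the same group gives a far larger rise (a 180-fold higher number from compound 1 to compound 3 (2.26 log units; beyond the scatter)), so the two ring-bearing groups, one a five-membered non-aromatic ring and the other a six-membered aromatic ring, both give much higher numbers than the propyl chain, and compound 3 now carries the highest number of the three. Nothing available here explains why these groups rank in this order.

From the compounds shown here alone, it remains open whether the rise follows from having a ring on this oxygen at all or from the nitrogen within the ring, a question that a phenyl or cyclopentyl group in the same place could help to separate. Going by these compounds, it is also open whether the low number of compound 1 depends on propyl itself, or whether a shorter ethyl chain or a longer butyl chain would serve equally well.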